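Thiourea-to-urea swap on a sugar-linked enone: cytotoxicity estimate

A few compounds are considered here, and "the series" means these few. Any claim that something is new, unique, unknown or untested is made for them only; others in the source may bear on it.

Measured compounds, all in an ADME assay on Vero cells (Chlorocebus sabaeus) for cytotoxicity, read by resazurin assay, with a stated time of 2 days; a higher number here means that more compound is tolerated, a lower number that less compound is tolerated:
Compound 1, `CC(=O)OC[C@H]1O[C@@H](CC(=O)/C=C/c2cccc(NC(=O)Nc3ccccc3)c2)[C@H](OC(C)=O)[C@@H](OC(C)=O)[C@@H]1OC(C)=O`: 180000 nM.
Compound 2, `O=C(/C=C/c1ccc(NC(=S)Nc2ccccc2)cc1)C[C@@H]1O[C@H](CO)[C@@H](O)[C@H](O)[C@H]1O`: 274000 nM.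
Compound 3, `CC(=O)OC[C@H]1O[C@@H](CC(=O)/C=C/c2cccc(NC(=S)Nc3ccccc3)c2)[C@H](OC(C)=O)[C@@H](OC(C)=O)[C@@H]1OC(C)=O`: 337000 nM.

Compound 3 and compound 1 differ in one place, (a group of 9 heavy atoms (7 carbon, 1 nitrogen, 1 oxygen; one six-membered aromatic ring of carbon only) in place of a group of 9 heavy atoms (7 carbon, 1 nitrogen, 1 sulfur; one six-membered aromatic ring of carbon only), on a nitrogen on an aromatic ring). That change gave a 1.9-fold lower number from compound 3 to compound 1 (0.27 log units; within the scatter). The core of compound 2 differs from the core of compound 3 by more than one place, and the difference between the two cores is not broken down here; compound 2 and compound 3 sit within the scatter of each other in this assay. Compound 4, `O=C(/C=C/c1ccc(NC(=O)Nc2ccccc2)cc1)C[C@@H]1O[C@H](CO)[C@@H](O)[C@H](O)[C@H]1O`, is the same kind of change applied to compound 2, namely (a group of 9 heavy atoms (7 carbon, 1 nitrogen, 1 oxygen; one six-membered aromatic ring of carbon only) in place of a group of 9 heavy atoms (7 carbon, 1 nitrogen, 1 sulfur; one six-membered aromatic ring of carbon only), on a nitrogen on an aromatic ring).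

Because the earlier step of a 1.9-fold lower number from compound 3 to compound 1 (0.27 log units; within the scatter) stayed within the scatter, a step of similar size is expected from compound 2 to compound 4: a 1.4-fold lower number from compound 2 to compound 4 (0.16 log units; within the scatter). Compound 4 is therefore estimated at 190000 nM, between 90000 nM and 400000 nM.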

Compound 4, half-maximal cytotoxic concentration: 1130000 nM
Compound 4: middle estimate off by 5.9-fold (0.77 log units), on the low side; measured number outside the range, above it.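

In this assay, putting phenylcarbamoyl in place of the sulfur-containing group on the aromatic ring's nitrogen, which turns the thiourea into a urea, gave a 4.1-fold higher number from compound 2 to compound 4 (0.62 log units; beyond the scatter). The result of this change did not carry over from one core to the other: the same change on two cores in this assay, a 1.9-fold lower number (0.27 log units; within the scatter) from compound 3 to compound 1 and a 4.1-fold higher number (0.62 log units; beyond the scatter) from compound 2 to compound 4, 7.7-fold (0.89 log units) apart, beyond the scatter of two such steps This shows that, for these two pairs, the step on one core does not predict the step on the other, but it does not show which of the several differences between the cores is responsible.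

The compounds shown leave open which of those differences matters. They also leave open how each core would respond to a guanidine in place of the urea or thiourea.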